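The source may report more compounds than this note shows. Statements on the series, on what has been measured and on what is new or still open speak of the compounds shown alone.

Three compounds built on one shared core have been run in a functional assay on HEK293 cells for agonist activity at Free fatty acid receptor 1 (Homo sapiens), read by fluorescence and calcium flux, with a stated time of 10 min; on this read-out lower numbers stand for an effect already at smaller amounts and higher numbers for an effect only at larger amounts of compound. Compound 1 `CC#C[C@@H](CC(=O)O)c1ccc(OC[C@H]2COc3ccc(Cl)cc3O2)cc1` gives 50 nM, compound 2 `CC#C[C@@H](CC(=O)O)c1ccc(OC[C@H]2COc3ccc(Br)cc3O2)cc1` gives 210 nM, and compound 3 `CC#C[C@@H](CC(=O)O)c1ccc(OC[C@H]2COc3ccc(C#N)cc3O2)cc1` gives 2100 nM; compound 3 therefore stands highest of the three, separated from the others by a 42-fold higher number from compound 1 to compound 3 (1.62 log units; beyond the scatter) and a 10-fold higher number from compound 2 to compound 3 (1.00 log units; beyond the scatter). Compound 4 `CC#C[C@@H](CC(=O)O)c1ccc(OC[C@H]2COc3ccc(C(=O)N4CCOCC4)cc3O2)cc1` differs from compound 3 by (morpholin-4-yl)carbonyl in place of cyano on an aromatic carbon. The measured steps, a 4.2-fold higher number from compound 1 to compound 2 (0.62 log units; beyond the scatter) and the two just named, exchange one halogen for another or put in a nitrile; none exchanges a nitrile for a carbonyl-linked ring, so none bears directly on this change. For the measured compounds named here, with no precedent, compound 4 is expected to stay near compound 3, with a step of a 1.4-fold lower number from compound 3 to compound 4 (0.15 log units; within the scatter) that may not exceed the scatter. The estimate for compound 4 in this assay is 1500 nM, within 300 nM to 8000 nM.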

Compound 4, half-maximal effective concentration: > 50000 nM
Compound 4 gave a limit, no number; the forecaster's own chance of this, stated with the estimate: 10%; middle value at least 33-fold (1.52 log units) away from the limit.
By their numbers in this assay, from the lowest: compound 1; then compound 2; then compound 3. At a limit, above all of these: compound 4.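

In this assay compound 4 gives only a limit, not a number: the limit of > 50000 nM in this assay, at which 1 of the 4 values shown sits.

For the compounds shown here, the earlier groups at this aromatic carbon, chloro, bromo and cyano, all gave measurable values, whereas (morpholin-4-yl)carbonyl, the only one with a ring, gives an at least 23-fold higher number from compound 3 to compound 4 (1.37 log units; beyond the scatter), an at least 230-fold higher number from compound 2 to compound 4 (2.37 log units; beyond the scatter) and an at least 1000-fold higher number from compound 1 to compound 4 (3.00 log units; beyond the scatter). The position therefore does not accept every group, and this change reaches further than any earlier step.

The compounds shown leave open whether the carbonyl link or the morpholine ring goes with this loss. A simple primary amide or a morpholin-4-ylmethyl group at this carbon would separate the two.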